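The source may report more compounds than this note shows. Statements on the series, on what has been measured and on what is new or still open speak of the compounds shown alone.

Compound 1, with the structure `CCN(CC)CN1C(=O)/C(=N/NC(N)=S)c2cc(Cl)ccc21`, is one of two measured members of this small series. In an ADME assay on Vero cells (Chlorocebus sabaeus) for cytotoxicity (a lower number here means that less compound is tolerated, a higher number that more compound is tolerated), compound 1 gives only a limit of the assay, > 100000 nM, not a number. Compound 2, with the structure `CCN(CC)CN1C(=O)/C(=N/NC(N)=S)c2ccccc21`, is the same skeleton with hydrogen in place of chloro on an aromatic carbon. In this assay compound 2 likewise reaches only a limit, > 100000 nM. The step from compound 1 to compound 2 is therefore a step that the two limits leave unreadable from compound 1 to compound 2; both values sit at the limit of > 100000 nM in this assay, at which 2 of the 2 values shown sit, so the size of that step cannot be read.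

The compound not yet measured, compound 3, has the structure `CCN(CC)CN1C(=O)/C(=N/NC(=S)Nc2ccc(Cl)cc2)c2cc(Cl)ccc21`. It differs from compound 1 by 4-chlorophenyl in place of hydrogen on an amide-type nitrogen, on the amide-type nitrogen whose other neighbour is the thiocarbonyl carbon. Among the measured compounds shown here, no measured step touches this nitrogen, so the single step on hand gives no guidance on its size or direction in this assay.

With only two limits to go on, the expected step from compound 1 to compound 3 is an at least 1.2-fold lower number from compound 1 to compound 3 (0.09 log units; that floor lies within the scatter). Compound 3 is therefore estimated at 80000 nM, in a range from 20000 nM to 200000 nM.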

Compound 3, minimum cytotoxic concentration: 100000 nM
Compound 3: middle estimate off by 1.3-fold (0.10 log units), on the low side; measured number inside the range.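

In this assay, among the compounds shown here, compound 3 gives 100000 nM, the first true number in this small series rather than a limit of the assay, so the amide-type nitrogen whose other neighbour is the thiocarbonyl carbon can carry a whole 4-chlorophenyl ring and still give a measurable value at this concentration. The change reads as a number no higher from compound 1 to compound 3 (the limit leaves the size open), which fixes a direction at most, and the size of this step cannot be read. Compound 1 has only a limit of the assay, not a number, so the true distance to the new value stays hidden: the limit of > 100000 nM in this assay, at which 2 of the 3 values shown sit.

The compounds shown leave open how other groups on this same nitrogen would read, for example a small methyl group, a plain phenyl ring without chlorine, or a phenyl ring carrying a carboxylic acid or an amine, and so whether the chlorine on the new ring plays any part in the result. Also open, as far as these compounds go, is whether 4-chlorophenyl on this nitrogen would read the same with hydrogen in place of chloro on the aromatic carbon of the shared core.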